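The source may report more compounds than this note shows. Statements on the series, on what has been measured and on what is new or still open speak of the compounds shown alone.

Measured in a functional assay on A549 cells (Homo sapiens) for antiproliferative activity, read by CCK-8 assay, with a stated time of 72 h; a lower number here means a stronger inhibitor, a higher number a weaker inhibitor:
- Compound 1 `COc1ccc(SCc2ccc(C(=O)Nc3ccccc3N)cc2)cc1`: 2570 nM
- Compound 2 `Nc1ccccc1NC(=O)c1ccc(CSc2cccc(F)c2)cc1`: "not determined" (no result reported)
- Compound 3 `Cc1ccc(SCc2ccc(C(=O)Nc3ccccc3N)cc2)cc1`: 3270 nM

In this assay, compound 3 gives 3270 nM, and this number lies within the scatter of compound 1 at 2570 nM. Compound 2 offers no number for comparison, so the series rests on just two values.

Compound 4 `Nc1ccccc1NC(=O)c1ccc(CSCCc2ccccc2)cc1` departs from compound 3 at the group on the sulfur, with phenethyl in place of 4-methylphenyl on a sulfur. Among the measured compounds shown here, only one measured step is available, a 1.3-fold higher number from compound 1 to compound 3 (0.10 log units; within the scatter), which puts methyl in place of methoxy on an aromatic carbon and stays within the scatter. For the measured compounds named here, that step shows little movement for one small swap, but it does not test the exchange made in compound 4, and no measured compound carries phenethyl. The data therefore give no direction for the change, and only a modest shift is expected, with wide uncertainty. The expected step is a 1.1-fold higher number from compound 3 to compound 4 (0.03 log units; within the scatter), which should not be read as a firm trend. For compound 4 the estimated value is 3500 nM, with an expected range from 1200 nM to 10000 nM.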

Compound 4, half-maximal inhibitory concentration: 3250 nM
The estimate for compound 4 lay 1.1-fold (0.03 log units) above the measured number; low and high end bracket the measured number.
By their numbers in this assay, from the lowest: compounds 1, 4 and 3 (each within the scatter of the next).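

Among the compounds shown here, compound 4 is the first test of the whole group on the sulfur, not just a small substituent on its aromatic ring. In this assay, replacing 4-methylphenyl with phenethyl gives a 1.0-fold lower number from compound 3 to compound 4 (0.00 log units; within the scatter), and replacing 4-methoxyphenyl with phenethyl gives a 1.3-fold higher number from compound 1 to compound 4 (0.10 log units; within the scatter), so at this position the assay separates none of the three groups, although phenethyl has 8 heavy atoms against 7 for 4-methylphenyl. No measurement is available that could explain this result.

All three groups compared here contain a six-membered aromatic ring of carbon only and have no hydrogen-bond donors or acceptors, so these compounds leave open whether the same flat picture would hold for a group on the sulfur without such a ring, such as a plain hexyl chain, or for one carrying an amine or a carboxylic acid. They also leave open how far the group can grow, since a longer chain between the sulfur and the aromatic ring lies outside this set.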